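Same atoms, joined differently: compound 2 to compound 4

The compounds below may be only part of what the source reports. "The series", "measured", "known", "first", "only" and "open" are said of these compounds alone.

- compound 1 `CC(Oc1c(N)ncc2c(-c3cnn(C4CCNCC4)c3)coc12)c1cc(F)ccc1Cl`: 6400 nM
- compound 2 `CC(Oc1c(N)ncc2c(-c3cnn(C4CCNCC4)c3)coc12)c1c(Cl)ccc(Cl)c1Cl`: 1300 nM
- compound 3 `COc1ccc(Cl)c([C@@H](C)Oc2c(N)ncc3c(-c4cnn(C5CCNCC5)c4)coc23)c1Cl`: 1600 nM

In a functional assay on MKN-45 cells (Homo sapiens) for antiproliferative activity, read by CellTiter-Glo, with a stated time of 3 days (on this read-out lower numbers stand for stronger inhibition and higher numbers for weaker inhibition), compound 2 gives 1300 nM, which lies within the usual scatter of compound 3 at 1600 nM. Compound 1 has a higher number, at 6400 nM.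

Compound 4 `CC(Oc1c(N)ncc2c(-c3cnn(C4CCNCC4)c3)coc12)c1c(Cl)cc(Cl)cc1Cl` has the same atoms as compound 2, joined differently: a group of 9 heavy atoms (6 carbon, 3 chlorine; one six-membered aromatic ring of carbon only) in place of a group of 9 heavy atoms (6 carbon, 3 chlorine; one six-membered aromatic ring of carbon only), on a saturated chain carbon bound to an oxygen on an aromatic ring and a saturated chain carbon. The group that enters is 2,4,6-trichlorophenyl.

Among the compounds with values here, only one measured step changes a group at this place: a 4.9-fold lower number from compound 1 to compound 2 (0.69 log units; beyond the scatter). That modest step goes beyond the scatter, but it alters which atoms the group carries. Within the data shown here, no measured step keeps those atoms and only rearranges them, so the evidence here is indirect. A smaller change in this assay therefore seems likely, though its direction is uncertain.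

The expected change is a 1.5-fold higher number from compound 2 to compound 4 (0.16 log units; within the scatter).

For compound 4 the estimate is 1900 nM, with an expected range of 700 nM to 6000 nM.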

Compound 4, half-maximal inhibitory concentration: 3600 nM
Compound 4: the middle estimate sits 1.9-fold (0.28 log units) below what was measured; low and high end bracket the measured number.
By their numbers in this assay, from the lowest: compounds 2 and 3 (each within the scatter of the next); then compounds 4 and 1 (each within the scatter of the next).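

Moving the chlorines alone is enough to shift the result in this assay: the atom counts stay the same, yet the number rises beyond the scatter (a 2.8-fold higher number from compound 2 to compound 4 (0.44 log units; beyond the scatter)). The step up from the earlier pair therefore does not come simply from carrying three chlorines on the ring, since 2,4,6-trichlorophenyl stays within the scatter of the 2-chloro-5-fluorophenyl group (a 1.8-fold lower number from compound 1 to compound 4 (0.25 log units; within the scatter)). Nothing measured here accounts for this difference between the two arrangements.

The compounds shown leave open how far this dependence on arrangement extends to other ring substituents. A trifluoromethyl group or a nitrile in place of one chlorine of compound 2, for example, could either keep or lose its number.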